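Methylation of the tetrazole in the naphthalene ether series

The compounds below may be only part of what the source reports. "The series", "measured", "known", "first", "only" and "open" are said of these compounds alone.

Three compounds of the shared core have numbers in an assay on isolated protein with Polyunsaturated fatty acid 5-lipoxygenase (Homo sapiens) as the target; on this read-out higher numbers stand for weaker inhibition and lower numbers for stronger inhibition. Compound 1 `CC(C)(O)c1cc(-c2ccccc2)c2ccc(OCc3cccc(C4(O)CCOCC4)c3)cc2c1` gives 1500 nM. Compound 2 `COCc1cc(-c2ccccc2)c2ccc(OCc3cccc(C4(O)CCOCC4)c3)cc2c1` gives 160 nM, the step being a 9.4-fold lower number from compound 1 to compound 2 (0.97 log units; beyond the scatter). Compound 3 `OC1(c2cccc(COc3ccc4c(-c5ccccc5)cc(-c5nn[nH]n5)cc4c3)c2)CCOCC1` carries a 2H-tetrazol-5-yl at the same aromatic carbon; in this assay compound 3 reports only a limit, > 6000 nM, not a number. Compound 3 thus sits at the limit of > 6000 nM in this assay, at which 1 of the 3 values shown sits. Going by the values given here, the two steps that lead into it, an at least 4.0-fold higher number from compound 1 to compound 3 (0.60 log units; beyond the scatter) and an at least 37-fold higher number from compound 2 to compound 3 (1.57 log units; beyond the scatter), both run toward weaker inhibition and are the only measured steps that touch the tetrazole.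

Compound 4 `Cn1nnc(-c2cc(-c3ccccc3)c3ccc(OCc4cccc(C5(O)CCOCC5)c4)cc3c2)n1` differs from compound 3 by methyl in place of hydrogen on an aromatic nitrogen. Among the compounds with values here, no measured pair covers a change on the tetrazole nitrogen itself, so direction and size rest on compound 3 alone, which is a limit. The step expected here is an at least 2.4-fold lower number from compound 3 to compound 4 (0.38 log units; beyond the scatter). Compound 4 is expected to give about 2500 nM in this assay, within a range of 500 nM to 12000 nM.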

Compound 4, half-maximal inhibitory concentration: 120 nM
Estimate against measurement, compound 4: 21-fold (1.32 log units) above; measured number outside the range, below it.
By their numbers in this assay, from the lowest: compounds 4 and 2 (each within the scatter of the next); then compound 1. At a limit, above all of these: compound 3.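

Going by these compounds alone, on the tetrazole, methyl in place of hydrogen on an aromatic nitrogen restores inhibition in this assay, with an at least 50-fold lower number from compound 3 to compound 4 (1.69 log units; beyond the scatter) as the measured step, whereas the earlier compounds showed the tetrazole at this aromatic carbon only as a loss. With a 1.3-fold lower number from compound 2 to compound 4 (0.12 log units; within the scatter) as the step, 2-methyl-2H-tetrazol-5-yl and methoxymethyl cannot be told apart at this position, so a tetrazole here need not cost inhibition once its nitrogen carries methyl. Set against 1-hydroxy-1-methylethyl, the same group gives a 13-fold lower number from compound 1 to compound 4 (1.10 log units; beyond the scatter) as its step.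

As far as these compounds go, compound 3 stands only as a limit, so the full size of the methyl step stays open: the limit of > 6000 nM in this assay, at which 1 of the 4 values shown sits. Also open, from the compounds shown here alone, is whether an ethyl group or a longer chain on the same ring nitrogen keeps this level, and whether a carboxylic acid on the same aromatic carbon follows compound 3.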